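Swapping a meta substituent on a urea: bromo next

The source may report more compounds than this note shows. Statements on the series, on what has been measured and on what is new or still open speak of the compounds shown alone.

Measured compounds:
compound 1, `CCc1cccc(NC(=O)N[C@H](C)c2ccccc2)c1` — 71%
compound 2, `CCOC(=O)c1cccc(NC(=O)N[C@H](C)c2ccccc2)c1` — 94%

Compound 2 stands highest of the two numbers in an ADME assay on the whole organism with Oryza sativa as the target, tested at 1 uM; a higher number here means a weaker effect of the compound at the concentration tested, a lower number a stronger effect; its nearest neighbour is compound 1, which lies a number 23 percentage points higher from compound 1 to compound 2 (beyond the scatter) below it. The compound to be measured next is compound 3, `C[C@@H](NC(=O)Nc1cccc(Br)c1)c1ccccc1`. It differs from compound 2 by bromo in place of ethoxycarbonyl on an aromatic carbon. Going by the values given here, the only measured step, a number 23 percentage points higher from compound 1 to compound 2 (beyond the scatter), concerns an exchange of ethyl for ethoxycarbonyl and does not involve bromo, so nothing measured bears directly on the change at hand. Among the compounds with values here, the one step seen was modest but beyond the scatter, and both compounds so far sit in the upper part of the scale in this assay. Compound 3 is therefore expected to stay in that upper region, with a drop of roughly a number 12 percentage points lower from compound 2 to compound 3 (beyond the scatter) from compound 2 considered plausible but not assured. The estimate for compound 3 is 82%, with a range from 62% to 100%.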

Compound 3, a percentage reported as activity, at one concentration (the size of the read-out at that concentration, not a potency): 100%
Estimate against measurement, compound 3: 18 percentage points below; low and high end bracket the measured number.
By their numbers in this assay, from the lowest: compound 1; then compounds 2 and 3 (each within the scatter of the next).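

In this assay, bromo in place of ethoxycarbonyl gives a number 6 percentage points higher from compound 2 to compound 3 (within the scatter), so at this place on the aromatic ring, two substituents with very different heavy-atom counts and hydrogen-bond acceptor counts cannot be told apart. Bromo in place of ethyl gives a number 29 percentage points higher from compound 1 to compound 3 (beyond the scatter), which shows that the earlier step from ethyl was not particular to ethoxycarbonyl: among these three compounds, ethyl alone stands apart. Nothing available explains this difference between ethyl and the other two substituents.

The compounds shown leave open whether the lower number belongs to ethyl alone or extends to other groups at this place, such as methyl, a longer alkyl chain or an amine. They also leave open whether a carboxylic acid would stay with bromo and ethoxycarbonyl.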